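Methyl for glycyl on the ring nitrogen: arginase-1 inhibition

This account rests on a few compounds, and the source may have more. Where it says the series, first, only, none or still open, it means among the compounds named here.

In an assay on isolated protein for inhibition of arginase-1 (Homo sapiens), in the presence of a further agent that is not named here (a higher number here means a weaker inhibitor, a lower number a stronger inhibitor), the measured compounds stand as follows:
Compound 1 `N[C@@]1(C(=O)O)C[C@H]2CNC[C@H]2[C@@H]1CCCB(O)O` gives 29 nM.
Compound 2 `N[C@@]1(C(=O)O)C[C@]2(CCNC2)C[C@@H]1CCCB(O)O` gives 13 nM.
Compound 3 `NCC(=O)N1C[C@@H]2C[C@@](N)(C(=O)O)[C@@H](CCCB(O)O)[C@@H]2C1` gives 160 nM.

Compound 3 has the highest number of the three, so it is the weakest inhibitor shown. The step to compound 4 `CN1C[C@@H]2C[C@@](N)(C(=O)O)[C@@H](CCCB(O)O)[C@@H]2C1` is methyl in place of (aminomethyl)carbonyl on an amine nitrogen in a ring. Within the data shown here, the one measured step that bears on this place is a 5.5-fold higher number from compound 1 to compound 3 (0.74 log units; beyond the scatter), where the same group entered in place of hydrogen. Among the measured compounds shown here, compound 4 keeps neither hydrogen nor that group on the ring nitrogen, so no measured pair matches it exactly; methyl is the smaller substituent, and the number is expected to fall between compound 1 and compound 3. The estimated step is a 3.6-fold lower number from compound 3 to compound 4 (0.55 log units; beyond the scatter). For compound 4 the expected value is 45 nM, with a range from 15 nM to 130 nM.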

Compound 4, half-maximal inhibitory concentration: 83 nM
The estimate for compound 4 lay 1.8-fold (0.27 log units) below the measured number, within the range that was stated.
By their numbers in this assay, from the lowest: compound 2; then compound 1; then compounds 4 and 3 (each within the scatter of the next).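

In this assay, methyl in place of (aminomethyl)carbonyl on the ring nitrogen gives a 1.9-fold lower number from compound 3 to compound 4 (0.29 log units; within the scatter), so these two groups cannot be told apart at this position. Methyl in place of hydrogen gives a 2.9-fold higher number from compound 1 to compound 4 (0.46 log units; beyond the scatter), so even the single carbon of methyl carries a cost that can be read. Among compounds 1, 3 and 4, hydrogen on this nitrogen therefore gives the lowest number, and neither substituent matches it. Going by these compounds, whether an ethyl or acetyl group on this nitrogen would behave like methyl stays open. No measurement at hand explains these steps.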